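Ester to Dimethylamide on a Naphthyl Pyridine Acrylate

This account rests on a few compounds, and the source may have more. Where it says the series, first, only, none or still open, it means among the compounds named here.

Measured compounds:
compound 1 `CCOC(=O)/C=C/c1ccncc1-c1ccc2ccccc2c1` — 53.3 nM
compound 2 `CN1CCN(c2ccc(Nc3cnccc3/C=C/C(N)=O)cc2)CC1` — "not determined" (no result reported)

In an assay on a protein complex for inhibition of CDK8/Cyclin C (Homo sapiens), with a stated time of 1 h (a lower number here means a stronger inhibitor, a higher number a weaker inhibitor), compound 1 gives 53.3 nM, the only numerical result in this set. For compound 2 the outcome in this assay is recorded as "not determined" (no result reported), so it offers no point of comparison, and compound 1 stands alone as the reference.

Compound 3 `CN(C)C(=O)/C=C/c1ccncc1-c1ccc2ccccc2c1` keeps the core of compound 1 and differs by one change: dimethylamino in place of ethoxy on a carbonyl carbon. Among the compounds with values here, no measured pair in this set shows the effect of such a change, so there is no step from which to read the size of the shift. The expectation is that the step from compound 1 to compound 3 stays modest, within or close to the usual scatter, and the estimate is a 1.5-fold higher number from compound 1 to compound 3 (0.18 log units; within the scatter). Compound 3 is therefore expected to give about 80 nM in this assay, in the range from 20 nM to 320 nM.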

Compound 3, half-maximal inhibitory concentration: 30.1 nM
Beside the measured number, compound 3's estimate is 2.7-fold (0.42 log units) above it, and the stated range covers the measured number.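

In this assay, within the data shown here, the first step that can be read at this carbonyl carbon runs a 1.8-fold lower number from compound 1 to compound 3 (0.25 log units; within the scatter), and it lies within the usual scatter of repeated measurements. Compound 1 alone could not show how much this position tolerates, whereas compound 3 shows that ethoxy and dimethylamino on the carbonyl carbon, with the shared core kept, give readings that the assay does not separate. Taken as one pair, the two compounds therefore show that the ethoxycarbonyl group is not needed for a reading of this order, since dimethylcarbamoyl serves equally well here.

On these data alone, whether the same holds for a carboxylic acid, a primary amine or a longer chain on that carbonyl carbon stays open, as this single pair cannot say how far the tolerance extends. Nothing given here accounts for the two groups reading alike.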